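This account rests on a few compounds, and the source may have more. Where it says the series, first, only, none or still open, it means among the compounds named here.

Compound 3 (`COc1ccc2c(=O)c(/C=C/C(=O)Nc3cc(C)ccc3C)coc2c1`) gives 1100000 nM in an ADME assay on HepG2 2.2.15 cells (Homo sapiens) for cytotoxicity, read by MTT assay, with stated times of 48 h and 9 days (a lower number here means that less compound is tolerated, a higher number that more compound is tolerated), and stands within the scatter of both compound 1 (`COc1ccc2c(=O)c(/C=C/C(=O)Nc3cccc(C)c3)coc2c1`) at 554000 nM and compound 2 (`COc1ccc(CNC(=O)/C=C/c2coc3cc(O)ccc3c2=O)cc1`) at 718000 nM on this read-out. Moving to compound 4 (`COc1ccc2c(=O)c(/C=C/C(=O)NCc3ccccc3F)coc2c1`) brings 2-fluorobenzyl in place of 2,5-dimethylphenyl on an amide-type nitrogen and so puts 2-fluorobenzyl in place of 2,5-dimethylphenyl on an amide-type nitrogen. Among the compounds with values here, no measured step covers this exchange itself. Within the data shown here, the only measured step is a 2.0-fold higher number from compound 1 to compound 3 (0.30 log units; within the scatter) for methyl in place of hydrogen on an aromatic carbon, and it bears on the change only loosely. The nearest comparison is compound 2, which also has a substituted benzyl on its amide nitrogen and gives 718000 nM in this assay on a core that is not identical. A change beyond the scatter is therefore not expected, and the direction is uncertain, with a slight lean towards a lower number. The expected change is a 1.5-fold lower number from compound 3 to compound 4 (0.17 log units; within the scatter) in this estimate. Compound 4 is expected at 750000 nM with an estimated range from 320000 nM to 1600000 nM on this read-out.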

Compound 4, half-maximal cytotoxic concentration: 146000 nM
The estimate for compound 4 lay 5.1-fold (0.71 log units) above the measured number; measured number below the stated range.
By their numbers in this assay, from the lowest: compound 4; then compounds 1, 2 and 3 (each within the scatter of the next).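

On the amide-type nitrogen, 2-fluorobenzyl in place of 2,5-dimethylphenyl gives a 7.5-fold lower number from compound 3 to compound 4 (0.88 log units; beyond the scatter) in this assay, and 2-fluorobenzyl in place of 3-methylphenyl gives a 3.8-fold lower number from compound 1 to compound 4 (0.58 log units; beyond the scatter). The earlier compounds shown here offered only a step within the scatter, for a methyl on an aromatic carbon, whereas these two steps show that exchanging the group on this nitrogen can move the number beyond the scatter, both times towards less compound being tolerated. Nothing at hand accounts for this shift.

The compounds shown leave open whether the step follows the fluorine or the benzyl form of the group, a question that plain benzyl on the same nitrogen would separate. They also do not tell how a different kind of group, such as a longer chain ending in an amine, would fare at this position.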